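The compounds below may be only part of what the source reports. "The series", "measured", "known", "first", "only" and "open" are said of these compounds alone.

Compound 1 `CN1CCN(CCCS(=O)(=O)c2ccc3nc(NC(=O)NC(=O)c4cc(C5CC5)ccc4Cl)sc3c2)CC1`: 2.9
Compound 2 `CN1CCN(CCCS(=O)(=O)c2ccc3nc(NC(=O)NC(=O)c4cc(-n5cccn5)c(Cl)cc4Cl)sc3c2)CC1`: 2.3

In a physicochemical assay for lipophilicity (on this read-out higher numbers stand for higher lipophilicity and lower numbers for lower lipophilicity), compound 1 gives 2.9, the higher of the two measured values; compound 2 gives 2.3, a gap below compound 1 that lies beyond the usual scatter. Compound 3 `CN1CCN(CCCS(=O)(=O)c2ccc3nc(NC(=O)NC(=O)c4cc5c(ccn5C)cc4Cl)sc3c2)CC1` has not yet been measured. It differs from compound 1 in a single place: 5-chloro-1-methyl-1H-indol-6-yl in place of 2-chloro-5-cyclopropylphenyl on a carbonyl carbon. Within the data shown here, no measured pair shows this particular change, so its effect is unknown. A step from compound 1 to compound 3 of about a number 0.10 log units lower from compound 1 to compound 3 (within the scatter) in this assay is expected, which would be no change beyond the scatter. Compound 3 is therefore estimated at 2.8, with a range from 2.3 to 3.3.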

Compound 3, distribution coefficient: 2.8
The estimate for compound 3 equals the measured number at the digits printed; the range from low to high includes it.
By their numbers in this assay, from the lowest: compound 2; then compounds 3 and 1 (each within the scatter of the next).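

On the carbonyl carbon, 5-chloro-1-methyl-1H-indol-6-yl in place of 2-chloro-5-cyclopropylphenyl gives a number 0.10 log units lower from compound 1 to compound 3 (within the scatter) in this assay. This single pair shows that, at this place, a five-membered aromatic ring with one hetero atom can stand in for a three-membered carbon ring without a shift beyond the scatter. No measurement shown explains the size of this step.

From the compounds shown here alone, whether a phenyl group carrying a carboxylic acid or an amine at this place would shift this assay beyond the scatter remains open.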